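From pentyl to cyclohexyl on compound 3

The source may hold more compounds than are shown below. What is called first, only, known or untested is meant among the compounds shown, and "the series" means these compounds.

Compound 1 `O=c1[nH]c(=O)c2nccnc2[nH]1`: 713000 nM
Compound 2 `Cc1cc(C)n(C)c2cccc(=O)c1-2`: 33000 nM
Compound 3 `CCCCCc1ccc(/C=C2\C(=O)NC(=O)C3=C2CCCC3)cc1`: 9200 nM

In a physicochemical assay for activation, with a stated time of 60 min (on this read-out higher numbers stand for an effect only at larger amounts of compound and lower numbers for an effect already at smaller amounts), compound 3 gives 9200 nM, the lowest of the three numbers. Compound 2 lies nearest to it and compound 1 furthest, both beyond the scatter. Compound 4 `O=C1NC(=O)/C(=C\c2ccc(C3CCCCC3)cc2)C2=C1CCCC2` has cyclohexyl in place of pentyl on an aromatic carbon. Within the data shown here, no measured pair shows what such a swap does, so the expectation remains open. No step beyond the scatter is expected in this assay, and the estimated step is a 1.0-fold lower number from compound 3 to compound 4 (0.01 log units; within the scatter). For compound 4 the estimated value is 9000 nM, with an expected range from 3500 nM to 24000 nM.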

Compound 4, half-maximal effective concentration: 121000 nM
For compound 4 the middle estimate is 13-fold (1.13 log units) below the measured one, and the stated range ends below it.
By their numbers in this assay, from the lowest: compound 3; then compound 2; then compound 4; then compound 1.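

In this assay, putting cyclohexyl in place of pentyl on an aromatic carbon gives a 13-fold higher number from compound 3 to compound 4 (1.12 log units; beyond the scatter), so this place responds strongly to the form of its carbon group. Neither group carries a hydrogen-bond donor, a hydrogen-bond acceptor or a net charge, so the step arises without any change in those counts. Nothing available explains the size of this step.

The swap adds a ring and changes the heavy-atom count together, and the compounds shown do not separate the two. Nor do they show how a hexyl chain or a cyclopentyl ring would read at this place.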